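The source may report more compounds than this note shows. Statements on the series, on what has been measured and on what is new or still open speak of the compounds shown alone.

Two members of the series have been measured in a functional assay on NCI-H460 cells (Homo sapiens) for inhibition, read by sulforhodamine B assay, with a stated time of 48 h; a lower number here means a stronger inhibitor of growth, a higher number a weaker inhibitor of growth. Compound 1 `O=C(/C(=C\c1c(-c2ccccc2)[nH]c2ccccc12)S(=O)(=O)c1ccccc1)c1ccccc1` gives 5900 nM there. Compound 2 `COc1ccc(-c2[nH]c3ccc(OC)cc3c2/C=C(\C#N)S(=O)(=O)c2ccccc2)cc1` gives 687 nM in this assay, the lowest of the two numbers; its nearest neighbour is compound 1, whose number is higher by a margin beyond the usual scatter. These two compounds differ in more than one place, so nothing is concluded about which change accounts for the gap.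

Compound 3 `COc1ccc(-c2[nH]c3ccccc3c2/C=C(\C#N)S(=O)(=O)c2ccccc2)cc1` is next for measurement in this assay. It differs from compound 2 in one place: hydrogen in place of methoxy on an aromatic carbon. Going by the values given here, no measured pair shows this change on its own, so its effect can only be estimated. The expected step is a 1.9-fold higher number from compound 2 to compound 3 (0.28 log units; within the scatter), a moderate rise in the number, though no change beyond the scatter cannot be ruled out. For compound 3 the estimated value in this assay is 1300 nM, with a range from 450 nM to 4000 nM.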

Compound 3, concentration for 50% growth inhibition: 404 nM
Compound 3: the middle estimate sits 3.2-fold (0.51 log units) above what was measured; the whole stated range lies above it.
By their numbers in this assay, from the lowest: compounds 3 and 2 (each within the scatter of the next); then compound 1.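

In this assay, hydrogen in place of methoxy on the aromatic carbon, meta to a fused ring and para to a fused ring, gives a 1.7-fold lower number from compound 2 to compound 3 (0.23 log units; within the scatter). Going by these compounds alone, this is the first pair that differs in one place, and it shows that the number of compound 2 does not depend on this methoxy: the position accepts the bare hydrogen without a change beyond the scatter. Nothing measured on these compounds accounts for the size of this step.

On these data alone, whether a larger or different group at this position, such as a chlorine, an amine or a longer alkoxy chain, would move the number beyond the scatter remains open. Within the data shown here, also open is what the second methoxy, which compound 3 retains, contributes, since no pair isolates it.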